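The compounds below may be only part of what the source reports. "The series", "measured", "known", "first", "only" and "open" are said of these compounds alone.

In a physicochemical assay for solubility, read by HPLC, in phosphate buffer, measured as kinetic solubility, at pH 7.4 (on this read-out higher numbers stand for higher solubility and lower numbers for lower solubility), compound 2 `CCC(=O)c1cc(-c2ccc(S(N)(=O)=O)cc2)n(-c2ccc(C(F)(F)F)cn2)n1` stands highest of the three measured compounds at 99400 nM while compound 3 `CCC(=O)c1cc(-c2ccc(S(N)(=O)=O)cc2)n(-c2ccc(Cl)cn2)n1` gives 33700 nM and compound 1 `CCOC(=O)c1cc(-c2ccc(F)cc2)n(-c2ccc(S(N)(=O)=O)cc2)c1N` gives 7500 nM on the same scale. Compound 4 `NS(=O)(=O)c1ccc(-c2cc(C(=O)N3CCCC3)nn2-c2ccc(C(F)(F)F)cn2)cc1` differs from compound 2 in one place, with pyrrolidin-1-yl in place of ethyl on a carbonyl carbon is the whole change. Among the compounds with values here, no measured step touches that carbon. Within the data shown here, the only step available, a 2.9-fold lower number from compound 2 to compound 3 (0.47 log units; beyond the scatter) for chloro in place of trifluoromethyl on an aromatic carbon, is modest and offers just a rough gauge of size. A similar modest move to a lower number is expected, estimated as a 2.2-fold lower number from compound 2 to compound 4 (0.34 log units; beyond the scatter) on thin evidence. For compound 4 the estimated value is 45000 nM with an expected range from 15000 nM to 120000 nM for now.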

Compound 4, solubility: 8800 nM
Beside the measured number, compound 4's estimate is 5.1-fold (0.71 log units) above it, and the stated range ends above it.
By their numbers in this assay, from the lowest: compounds 1 and 4 (each within the scatter of the next); then compound 3; then compound 2.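

In this assay the carbonyl carbon proves to be a place where one change can move the number a long way, a large step (an 11-fold lower number from compound 2 to compound 4 (1.05 log units; beyond the scatter)) for pyrrolidin-1-yl in place of ethyl. Within the data shown here, this is the first reading at this carbon, and here the group grows from 2 heavy atoms to 5 and gains a ring. No measurement shown explains the fall. Among these compounds, with only this one change at the carbon, the effects of the ring, its nitrogen and the added atoms cannot be told apart. On these data alone, whether an open-chain amine such as dimethylamino or a morpholine ring on the same carbonyl carbon would give a similar number remains open.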